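Chloro for Trifluoromethyl on a Shared Core

A few compounds are considered here, and "the series" means these few. Any claim that something is new, unique, unknown or untested is made for them only; others in the source may bear on it.

Going by the values given here, compound 2 `COc1cc2cc(Oc3ccc(NC(=O)Nc4ccc(Cl)c(C(F)(F)F)c4)cc3)c(C)nc2cc1OC` is one of two compounds measured so far on this core. In a functional assay on DU-145 cells (Homo sapiens) for inhibition, read by sulforhodamine B assay, with a stated time of 48 h, tested at 10 uM (a higher number here means a weaker effect of the compound at the concentration tested, a lower number a stronger effect), compound 2 gives 12.7%, the lowest of the two numbers; its nearest neighbour is compound 1 `COc1cc2cc(Oc3ccc(NC(=O)Nc4ccccc4)cc3)c(C)nc2cc1OC`, which in this assay gives 88.7%. Among the compounds with values here, the single measured step, a number 76 percentage points lower from compound 1 to compound 2 (beyond the scatter), brought in the chloro and the trifluoromethyl group together, so it bears only in part on the change now at hand. Compound 3 `COc1cc2cc(Oc3ccc(NC(=O)Nc4ccc(Cl)c(Cl)c4)cc3)c(C)nc2cc1OC` differs from compound 2 by chloro in place of trifluoromethyl on an aromatic carbon, while the chloro already present stays. Within the data shown here, with no measured step that separates the two groups, the expected step in this assay is small, a number 5.3 percentage points higher from compound 2 to compound 3 (within the scatter), and within the scatter. Compound 3 is therefore estimated at 18%, with a range from 7% to 40%.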

Compound 3, a percentage reported as activity, at one concentration (the size of the read-out at that concentration, not a potency): 24.8%
Compound 3: middle estimate off by 6.8 percentage points, on the low side; the measured number falls inside the stated range.
By their numbers in this assay, from the lowest: compound 2; then compound 3; then compound 1.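

In this assay, putting chloro in place of trifluoromethyl gives a number 12.1 percentage points higher from compound 2 to compound 3 (beyond the scatter), so the two groups can now be told apart on this aromatic carbon, and trifluoromethyl gives the stronger effect by a modest margin. The other new step, a number 63.9 percentage points lower from compound 1 to compound 3 (beyond the scatter), shows that most of the large gain over the unsubstituted phenyl remains with 3,4-dichlorophenyl, so that gain does not depend on trifluoromethyl. Nothing available explains why the two groups differ.

As far as these compounds go, it remains open how an amine, a methoxy group or a nitrile would behave on this same carbon. From the compounds shown here alone, it is also open how much of the effect a phenyl carrying a single chloro would keep, and whether the order of compound 2 and compound 3 holds on other cell lines.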